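A few compounds are considered here, and "the series" means these few. Any claim that something is new, unique, unknown or untested is made for them only; others in the source may bear on it.

In a physicochemical assay for metabolic stability, read by HPLC, in phosphate buffer, at pH 7.4, tested at 10 uM (a lower number here means that the compound disappears faster, a higher number that the compound lasts longer), compound 1 `O=C(c1ccccc1)c1ccc2c(c1)oc(=O)n2C(=O)NCCCCc1ccccc1` gives 1.63 h and stands lowest of the two measured compounds. Compound 2 `O=C(NCCCCc1ccccc1)n1c(=O)oc2ccc(-c3ccccc3)cc21` gives 4.93 h and lies higher, by a gap beyond the usual scatter. The next compound, compound 3 `O=C(NCCCCc1ccccc1)n1c(=O)oc2cc(Br)ccc21`, departs from compound 1 in one place only, with bromo in place of benzoyl on an aromatic carbon and the rest of the structure unchanged. Within the data shown here, no pair of measured compounds shows this change on its own, so any forecast remains loose. With only compound 1 at 1.63 h and compound 2 at 4.93 h to go on, a half-life for compound 3 is expected to fall somewhere between the two. The expected step of a 1.8-fold higher number from compound 1 to compound 3 (0.26 log units; within the scatter) is thus a small rise, which may stay within the scatter. For compound 3 the estimate is 3 h (expected range 1.3 h to 7 h).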

Compound 3, half-life: 0.4 h
Compound 3: middle estimate off by 7.5-fold (0.88 log units), on the high side; the measured number lies below the stated range.
By their numbers in this assay, from the lowest: compound 3; then compound 1; then compound 2.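

In this assay, the group on this aromatic carbon clearly matters: bromo in place of benzoyl gives a 4.1-fold lower number from compound 1 to compound 3 (0.61 log units; beyond the scatter), so the position is not indifferent to the change. The swap replaces eight heavy atoms, including a six-membered aromatic ring and a double bond outside aromatic rings, with a single bromine atom, and here the compound carrying the single atom has the shorter half-life. No measurement at hand bears on what lies behind this step.

As far as these compounds go, with one pair at this position, it remains open which part of benzoyl counts, and whether the bare phenyl ring, a methoxy group, chloro or an amine on the same carbon would sit nearer to compound 1 or compound 3. From the compounds shown here alone, whether the step would hold with a shorter chain on the amide nitrogen also remains open.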